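The source may report more compounds than this note shows. Statements on the series, on what has been measured and on what is new or still open speak of the compounds shown alone.

Compound 1 `O=C(COc1ccc(C(=O)/C=C/c2cccc(Cl)c2)cc1)N[C@H]1CCOC1=O` and compound 3 `O=C(COc1ccc(C(=O)/C=C/c2cccc(F)c2)cc1)N[C@H]1CCOC1=O` share a core and differ at one aromatic carbon: chloro in place of fluoro on an aromatic carbon. In a functional assay on DU-145 cells (Homo sapiens) for antiproliferative activity, read by MTT assay, with a stated time of 72 h (on this read-out higher numbers stand for weaker inhibition and lower numbers for stronger inhibition), compound 3 gives 17200 nM, and compound 1 gives 3700 nM. That change brings a 4.6-fold lower number from compound 3 to compound 1 (0.67 log units; beyond the scatter).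

Compound 2 `O=C(CNc1ccc(F)cc1)N[C@H]1CCOC1=O` is built on a different core; how the two cores differ is not broken down here. In this assay compound 2 reaches only the limit of measurement, (the limit of > 64000 nM in this assay, at which 1 of the 3 values shown sits), so its value is > 64000 nM and no number is known for it.

Compound 4 `O=C(CNc1ccc(Cl)cc1)N[C@H]1CCOC1=O`, which is not yet measured, stands to compound 2 as compound 1 stands to compound 3: chloro in place of fluoro on an aromatic carbon. Here the place is para to a large group rather than meta to it, so this is the same kind of change, not the same change.

In this assay compound 4 is expected to show an at least 1.2-fold lower number from compound 2 to compound 4 (0.10 log units; that floor lies within the scatter), resting on the step seen from compound 3 to compound 1, a 4.6-fold lower number from compound 3 to compound 1 (0.67 log units; beyond the scatter), applied to a starting point that is only a limit. Compound 4 is therefore estimated at 50000 nM, between 15000 nM and 200000 nM.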

Compound 4, half-maximal inhibitory concentration: > 64000 nM
Compound 4 gave a limit, no number (the forecaster's own chance of this, stated with the estimate: 60%); middle value at least 1.2-fold (0.10 log units) away from the limit.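

In this assay compound 4 gives > 64000 nM, which is a limit and not a number. Compound 2 also stands at a limit, so no step can be read between compound 2 and compound 4: the limit of > 64000 nM in this assay, at which 2 of the 4 values shown sit.

The compounds shown leave open whether chloro in place of fluoro at this place changes antiproliferative activity at all.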